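A Hydroxy Group Enters the Imine Chain of Compound 3

A few compounds are considered here, and "the series" means these few. Any claim that something is new, unique, unknown or untested is made for them only; others in the source may bear on it.

Compound 3 `CCC/N=C(\C)c1c(O)c2ccccc2[nH]c1=O` was examined in an assay on isolated protein for inhibition of myosin-2 (Bos taurus), read by spectrophotometry, with a stated time of 24 min; on this read-out lower numbers stand for stronger inhibition and higher numbers for weaker inhibition. In this assay compound 3 gives >= 100000 nM, which is a limit of the assay and not a number. Its two measured neighbours sit in the same place: compound 1 `C/C(=N\C(C)C)c1c(O)c2ccccc2[nH]c1=O` gives >= 100000 nM, a limit. Compound 2 `CCC(C)/N=C(\C)c1c(O)c2ccccc2[nH]c1=O` gives >= 100000 nM, also a limit. The steps among them, a step that the two limits leave unreadable from compound 1 to compound 2, a step that the two limits leave unreadable from compound 1 to compound 3 and a step that the two limits leave unreadable from compound 2 to compound 3, are accordingly unreadable, since all three values stand at the limit of >= 100000 nM in this assay, at which 3 of the 3 values shown sit. Compound 4 `C/C(=N\CCO)c1c(O)c2ccccc2[nH]c1=O` differs from compound 3 by hydroxy in place of methyl on a saturated chain carbon, two bonds along the chain from a double-bonded nitrogen. With no readable step to lean on, the change toward compound 4 is expected to leave it at the limit as well, a number no higher from compound 3 to compound 4 (the limit leaves the size open). Compound 4 is therefore estimated at 100000 nM, with a range from 30000 nM to 300000 nM.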

Compound 4, half-maximal inhibitory concentration: >= 100000 nM
Compound 4 ended at the assay's limit; the forecaster's own chance of this, stated with the estimate: 85%; the middle value sits exactly at the limit.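

Going by these compounds alone, compound 4 joins compound 1, compound 2 and compound 3, so no step to compound 4 can be read, because each value is only a limit: the limit of >= 100000 nM in this assay, at which 4 of the 4 values shown sit. The compounds shown leave open what hydroxy in place of methyl does to inhibition of myosin-2.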